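This account rests on a few compounds, and the source may have more. Where it says the series, first, only, none or still open, it means among the compounds named here.

Going by the values given here, in an ADME assay on L6 cells (Rattus norvegicus) for cytotoxicity (a lower number here means a stronger inhibitor, a higher number a weaker inhibitor), compound 2 (`COc1ccc(C(=N)N)cc1-c1cc2cc(C(=N)N)ccc2o1`) gives 179000 nM and holds the higher of the two numbers so far, while compound 1 (`N=C(N)c1cccc(-c2cc3cc(C(=N)N)ccc3o2)c1`) gives 21200 nM in the same read-out. The next change leads to compound 3 (`N=C(N)c1ccc(O)c(-c2cc3cc(C(=N)N)ccc3o2)c1`): hydrogen in place of methyl on an oxygen on an aromatic ring in short methoxy to hydroxy. Among the compounds with values here, one measured step bears on this: an 8.4-fold higher number from compound 1 to compound 2 (0.93 log units; beyond the scatter) for methoxy in place of hydrogen on an aromatic carbon. Within the data shown here, no hydroxy compound has been measured yet, so that step is only a partial guide. Compound 3 keeps the oxygen, so a partial return towards compound 1 is expected, not a full one. The expected move in this assay is a lower number, a 3.0-fold lower number from compound 2 to compound 3 (0.47 log units; beyond the scatter) by this estimate. For compound 3 the estimated value is 60000 nM with an expected range from 18000 nM to 180000 nM in this read-out.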

Compound 3, half-maximal inhibitory concentration: > 217000 nM
Compound 3 gave a limit, no number; the forecaster's own chance of this, stated with the estimate: 10%; middle value at least 3.6-fold (0.55 log units) away from the limit.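

In this assay compound 3 gives a limit, > 217000 nM, and not a number. Against hydrogen on this aromatic carbon, hydroxy gives an at least 10-fold higher number from compound 1 to compound 3 (1.01 log units; beyond the scatter), so removing the methyl brings no return towards compound 1, and both oxygen-bearing compounds stand on the high side of it. Against methoxy, the change gives an at least 1.2-fold higher number from compound 2 to compound 3 (0.08 log units; that floor lies within the scatter), so compound 2 and compound 3 cannot be put in order beyond the scatter, and the methyl is not shown to matter here.

From the compounds shown here alone, the actual value of compound 3 remains unknown behind its limit. Whether the oxygen itself goes with the higher numbers remains open, as an amine or a fluorine on this carbon, or a longer chain such as ethoxy, lies outside the compounds shown.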